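The source may report more compounds than this note shows. Statements on the series, on what has been measured and on what is new or still open speak of the compounds shown alone.

Of the compounds shown here, three have so far been tested in an assay for binding affinity to Apoptosis regulator Bcl-2 (Homo sapiens), read by fluorescence polarization, with stated times of 30 min and 20 min, tested at 100 uM; on this read-out lower numbers stand for less inhibition and higher numbers for more inhibition at the one concentration tested (going by the name of the read-out). Compound 1 `COc1ccc(Oc2ccc([N+](=O)[O-])cc2-c2ccsc2S(=O)(=O)N2CCN(C(=S)Nc3ccc(Cl)cc3)CC2)cc1OC` gives 18%, and compound 2 `COc1ccc(Oc2ccc([N+](=O)[O-])cc2-c2ccsc2S(=O)(=O)N2CCN(C(=S)Nc3ccc([N+](=O)[O-])cc3)CC2)cc1OC` gives 16%. These two differ in a single place: nitro in place of chloro on an aromatic carbon. That change made a number 2 percentage points lower from compound 1 to compound 2 (within the scatter). Compound 3 `O=S(=O)(c1sccc1-c1ccccc1Oc1ccc(O)c(O)c1)N1CCN(C(=S)Nc2ccc(Cl)cc2)CC1` gives 2% in this assay, the lowest of the three numbers; the difference between its core and the core of compound 1 is not broken down here.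

Compound 4 `O=[N+]([O-])c1ccc(NC(=S)N2CCN(S(=O)(=O)c3sccc3-c3ccccc3Oc3ccc(O)c(O)c3)CC2)cc1` has not yet been measured in this assay. It differs from compound 3 by nitro in place of chloro on an aromatic carbon, the same change as between compound 1 and compound 2, and at a place described in the same way. Where that change was already made, it produced a number 2 percentage points lower from compound 1 to compound 2 (within the scatter), a shift within the scatter. On that single earlier case rests the expectation that the new step will likewise be small, estimated at no change at the digits printed from compound 3 to compound 4 (within the scatter). Compound 4 is accordingly expected to give about 2% in this assay, with a likely range from -6% to 12%. The measurement will show whether this holds.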

Compound 4, a percentage reported as inhibition, at one concentration (the size of the read-out at that concentration, not a potency): 31%
Compound 4: middle estimate off by 29 percentage points, on the low side, outside the stated range (above it).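

In this assay, nitro in place of chloro gave a number 29 percentage points higher from compound 3 to compound 4 (beyond the scatter), whereas the same swap on the core of compound 1 stayed within the scatter. The size of this step therefore did not carry over from one core to the other: the same change on two cores in this assay, a number 2 percentage points lower (within the scatter) from compound 1 to compound 2 and a number 29 percentage points higher (beyond the scatter) from compound 3 to compound 4, 31 percentage points apart, beyond the scatter of two such steps. In this series, then, the step seen on one of these cores is a poor guide to the step on the other, but two pairs do not show what in the cores sets the steps apart, nor how the change would behave on any further core.

The compounds shown carry only chloro and nitro at this place on the six-membered aromatic ring, so it stays open how an amine, a carboxylic acid or a nitrile there would read on either core. As far as these compounds go, each number is also a reading at one concentration and not a potency, and how compound 4 would behave across a range of concentrations stays open.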